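Trimming an Ethyl Urea Back to Methyl

The source may report more compounds than this note shows. Statements on the series, on what has been measured and on what is new or still open speak of the compounds shown alone.

Compound 1 `N#CC1CN1C(N)=O` carries a urea with two bare hydrogens on the shared core. In a functional assay on RPMI-8226 cells (Homo sapiens) for inhibition (a lower number here means a stronger inhibitor, a higher number a weaker inhibitor), compound 1 gives 432000 nM. Compound 2 `CCNC(=O)N1CC1C#N` differs in a single place, an ethyl in place of hydrogen on an amide-type nitrogen, and in this assay compound 2 gives 26000 nM. Among the compounds with values here, that one measured step, a 17-fold lower number from compound 1 to compound 2 (1.22 log units; beyond the scatter), is the whole of the comparison so far, so compound 2 stands with the lowest of the two numbers and compound 1 as its only neighbour, well beyond the scatter above it.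

Compound 3 `CNC(=O)N1CC1C#N` is the halfway house: hydrogen in place of methyl on a saturated chain carbon bound to an amide-type nitrogen. Within the data shown here, only the step from compound 1 to compound 2 bears on it, and that step was large. Compound 3 keeps one carbon of the chain, so a rise in the number in this assay that is real but smaller than the measured step is expected, because the full removal gave a 17-fold lower number from compound 1 to compound 2 (1.22 log units; beyond the scatter). Compound 3 is estimated at 65000 nM, within a range of 25000 nM to 170000 nM. That estimate means an expected step of a 2.5-fold higher number from compound 2 to compound 3 (0.40 log units; beyond the scatter).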

Compound 3, half-maximal inhibitory concentration: 26000 nM
Compound 3: middle estimate off by 2.5-fold (0.40 log units), on the high side; the range from low to high includes it.
By their numbers in this assay, from the lowest: compounds 2 and 3 (each within the scatter of the next); then compound 1.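

In this assay the methyl urea and the ethyl urea cannot be told apart, with no change at the digits printed from compound 2 to compound 3 (within the scatter) on record for the change of methyl to hydrogen on a saturated chain carbon bound to an amide-type nitrogen. The large step also appears with the shorter group, as a 17-fold lower number from compound 1 to compound 3 (1.22 log units; beyond the scatter) shows that methyl on the amide-type nitrogen is enough to give the same drop in the number as ethyl, so among these three compounds the outer carbon of the ethyl adds nothing that rises above the scatter. Nothing available explains why replacing hydrogen on this nitrogen matters so much while lengthening methyl to ethyl does not.

As far as these compounds go, whether the number stays at this level with a longer chain such as propyl or butyl, or with a branched group such as isopropyl, remains open. Also open, from the compounds shown here alone, is what a ring on this nitrogen, such as cyclopropyl or phenyl, or a hydroxyl group at the end of the chain would do in this assay on the shared core.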